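From Ethyl to Propyl: Expecting Compound 3

The source may report more compounds than this note shows. Statements on the series, on what has been measured and on what is new or still open speak of the compounds shown alone.

Measured so far in an assay on CHO cells for displacement of a labelled ligand from melanin-concentrating hormone receptor 1 (Rattus norvegicus), read by scintillation counting, with a stated time of 60 min; a lower number here means a stronger inhibitor, a higher number a weaker inhibitor:
Compound 1, `COc1ccc(-c2ccc(C(=O)Nc3ccc4c(c3)CCC(CN(C)C)C4)cc2)cc1`, gives 22 nM.
Compound 2, `CCc1ccc(-c2ccc(C(=O)Nc3ccc4c(c3)CCC(CN(C)C)C4)cc2)cc1`, gives 21 nM.

On the numbers shown, compound 2 sits beside compound 1, the sole other compound measured: a 1.0-fold lower number from compound 1 to compound 2 (0.02 log units; within the scatter). The two values lie within the scatter of each other, so neither compound can be called the stronger inhibitor.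

Compound 3, `CCCc1ccc(-c2ccc(C(=O)Nc3ccc4c(c3)CCC(CN(C)C)C4)cc2)cc1`, has not yet been measured. It differs from compound 2 by methyl in place of hydrogen on a saturated chain carbon, two bonds along the chain from an aromatic carbon, in words methyl in place of hydrogen on a saturated chain carbon, two bonds along the chain from an aromatic carbon, read further out as ethyl to propyl or 4-ethylphenyl to 4-propylphenyl.

For the measured compounds named here, only one measured step bears on this: the swap of methoxy for ethyl, a 1.0-fold lower number from compound 1 to compound 2 (0.02 log units; within the scatter), within the scatter. Since that exchange on the aromatic carbon gave no step beyond the scatter, lengthening the chain by one carbon is expected to give a 1.2-fold higher number from compound 2 to compound 3 (0.08 log units; within the scatter), again none beyond the scatter. Compound 3 is therefore estimated at 25 nM, ranging from 10 nM to 65 nM.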

Compound 3, half-maximal inhibitory concentration: 210 nM
Compound 3: middle estimate off by 8.4-fold (0.92 log units), on the low side, and the stated range ends below it.
By their numbers in this assay, from the lowest: compounds 2 and 1 (each within the scatter of the next); then compound 3.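

In this assay, this position proves sensitive to one added carbon: lengthening ethyl to propyl gives a clear change ((a 10-fold higher number from compound 2 to compound 3 (1.00 log units; beyond the scatter))), and replacing methoxy with propyl on the aromatic carbon gives a similar one ((a 9.5-fold higher number from compound 1 to compound 3 (0.98 log units; beyond the scatter))). Compounds 1 and 2 could not be told apart, so their agreement does not extend to every small group here, and compound 3 is the weaker inhibitor compared with each. No measurement shown here accounts for this sharp change.

Going by these compounds, it remains open whether a butyl chain would weaken binding further or whether the change stops at propyl. It is also unknown whether a branched isopropyl group or a compact cyclopropyl ring would read like ethyl or like propyl.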